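N-Alkylation of the fluoroindanylidene acetamide series

This account rests on a few compounds, and the source may have more. Where it says the series, first, only, none or still open, it means among the compounds named here.

Compound 1 `O=C(/C=C1\CCc2ccc(F)cc21)NCC1CC1`: 0%
Compound 2 `CCNC(=O)/C=C1\CCc2ccc(F)cc21`: 45%
Compound 3 `CNC(=O)/C=C1\CCc2ccc(F)cc21`: 45%

In a functional assay on the whole organism with Rattus norvegicus as the target, at a dose of 20 mg/kg by the oral route (on this read-out higher numbers stand for more inhibition at the one dose given (going by the name of the read-out) and lower numbers for less inhibition), compound 3 gives 45%, level with compound 2 and the highest value reached among these three; its only separation is from compound 1, a step of a number 45 percentage points higher from compound 1 to compound 3 (beyond the scatter). Compound 4 `CCN(C)C(=O)/C=C1\CCc2ccc(F)cc21` differs from compound 3 by ethyl in place of hydrogen on an amide-type nitrogen. Within the data shown here, no measured step alters the amide-type nitrogen itself; the nearest is no change at the digits printed from compound 2 to compound 3 (within the scatter), which lies within the scatter, while a number 45 percentage points higher from compound 1 to compound 2 (beyond the scatter) shows that a bulkier group on the saturated chain carbon lowers the read-out. Compound 4 is therefore expected to show little change or a modest fall, an estimated step of a number 15 percentage points lower from compound 3 to compound 4 (beyond the scatter). For compound 4 the expected value is 30%, ranging from 5% to 55%.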

Compound 4, a percentage reported as inhibition, in the whole organism at one dose (the size of the read-out at that dose, not a potency): 20%
For compound 4 the middle estimate is 10 percentage points above the measured one, within the range that was stated.
By their numbers in this assay, from the lowest: compound 1; then compound 4; then compounds 2 and 3 (each within the scatter of the next).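

Substitution on the amide-type nitrogen itself lowers the read-out in this assay: ethyl in place of hydrogen gives a number 25 percentage points lower from compound 3 to compound 4 (beyond the scatter), and methyl in place of hydrogen gives a number 25 percentage points lower from compound 2 to compound 4 (beyond the scatter). Losing the amide hydrogen does not remove the effect entirely, since (cyclopropylmethyl)amino to ethyl(methyl)amino gives a number 20 percentage points higher from compound 1 to compound 4 (beyond the scatter). Nothing measured here accounts for these steps.

The compounds shown leave open how a plain unsubstituted amine in place of methylamino, or a longer chain such as propyl on this nitrogen, would read.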